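A Ring Swap on the Shared Core: Compound 2 to Compound 4

The compounds below may be only part of what the source reports. "The series", "measured", "known", "first", "only" and "open" are said of these compounds alone.

Of the compounds shown here, three built on one shared core have been measured in a functional assay on LOX IMVI cells (Homo sapiens) for cytotoxicity, read by MTT assay, with a stated time of 24 h; a lower number here means a stronger inhibitor, a higher number a weaker inhibitor. Compound 1 `COc1cc(-c2nc(-c3ccccc3)[nH]c2-c2ccnc(NCCCNS(=O)(=O)c3ccc(Br)cc3)n2)ccc1F` gives 33900 nM, compound 2 `COc1cc(-c2nc(-c3ccccc3)[nH]c2-c2ccnc(NCCCNS(=O)(=O)c3ccc(C)cc3)n2)ccc1F` gives 2590 nM, and compound 3 `COc1cc(-c2nc(-c3ccccc3)[nH]c2-c2ccnc(NCCCNS(=O)(=O)c3cccc4ccccc34)n2)ccc1F` gives 14900 nM. Compound 2 therefore holds the lowest number of the three: the step of a 13-fold lower number from compound 1 to compound 2 (1.12 log units; beyond the scatter) and the step of a 5.8-fold higher number from compound 2 to compound 3 (0.76 log units; beyond the scatter) both lie beyond the scatter, as does the smaller step of a 2.3-fold lower number from compound 1 to compound 3 (0.36 log units; beyond the scatter).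

Compound 4 `Cc1ccc(S(=O)(=O)NCCCNc2nccc(-c3[nH]c(-c4ccccc4)nc3-c3ccc(Cl)c(O)c3)n2)cc1` differs from compound 2 in a single place: 4-chloro-3-hydroxyphenyl in place of 4-fluoro-3-methoxyphenyl on an aromatic carbon. All three measured steps concern the group on the sulfonyl sulfur, not the aromatic carbon of the five-membered aromatic ring with 2 nitrogen where this new change sits, so none of them bears directly on it. Going by the values given here, the only guidance the series offers is that single changes elsewhere have shifted the number in this assay by modest to large amounts in either direction. Among the compounds with values here, with no step of the same kind to lean on, a number close to that of compound 2 is expected, carrying a wide range, so that the step of a 1.0-fold higher number from compound 2 to compound 4 (0.00 log units; within the scatter) is expected to stay within the scatter. In this assay compound 4 is accordingly estimated at 2600 nM, with a range from 800 nM to 9000 nM.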

Compound 4, half-maximal inhibitory concentration: 6020 nM
Compound 4: the middle estimate sits 2.3-fold (0.36 log units) below what was measured; low and high end bracket the measured number.
By their numbers in this assay, from the lowest: compound 2; then compound 4; then compound 3; then compound 1.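

In this assay, going by these compounds alone, a 2.3-fold higher number from compound 2 to compound 4 (0.37 log units; beyond the scatter) gives the first reading at this place, the aromatic carbon of the five-membered aromatic ring with 2 nitrogen, and it shows that the number responds to a change here as well as on the sulfonyl sulfur. This modest step is smaller than a 5.8-fold higher number from compound 2 to compound 3 (0.76 log units; beyond the scatter) and a 13-fold lower number from compound 1 to compound 2 (1.12 log units; beyond the scatter), both seen on the sulfonyl side, although the comparison rests on only these few pairs. The swap alters the halogen and the oxygen substituent together, and it brings in a hydrogen-bond donor absent from 4-fluoro-3-methoxyphenyl, while nothing available explains why the number rises.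

The compounds shown leave open which part of the swap carries the step, a question that 4-chloro-3-methoxyphenyl or 4-fluoro-3-hydroxyphenyl at this place would address directly. They also leave open how an amine in place of the hydroxyl would read, and whether the same swap would move the number similarly with 4-bromophenyl or naphthalen-1-yl on the sulfonyl sulfur.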